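The compounds below may be only part of what the source reports. "The series", "measured", "known", "first", "only" and "open" are said of these compounds alone.

In a functional assay on IMR-32 cells (Homo sapiens) for antiproliferative activity, read by MTT assay (a higher number here means a weaker inhibitor, a lower number a stronger inhibitor), compound 1 (`Cc1c(-n2cc(COc3ccc(/C=C/C(=O)c4ccc5c(c4O)CCC(C)(C)O5)cc3)nn2)cccc1[N+](=O)[O-]`) gives 73500 nM. Compound 2 (`CCc1ccccc1-n1cc(COc2ccc(/C=C/C(=O)c3ccc4c(c3O)CCC(C)(C)O4)cc2)nn1`) is reported only as "not active" (no number reported), so it has no number and cannot be placed numerically beside compound 1. Compound 3 (`CCCCCCCCn1cc(COc2ccc(/C=C/C(=O)c3ccc4c(c3O)CCC(C)(C)O4)cc2)nn1`) has octyl in place of 2-ethylphenyl on an aromatic nitrogen. For the measured compounds named here, no measured step shows what such a swap does. Going by the values given here, the only number available, from compound 1 at 73500 nM, is a weak one, so at most a modest move toward a lower number is expected in this assay, and compound 3 may also show no activity. Compound 3 is estimated at 40000 nM, with an expected range of 10000 nM to 100000 nM.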

Compound 3, half-maximal inhibitory concentration: "not active" (no number reported)
Compound 3: no number reported; no gap can be computed for the estimate.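

Compound 2 and compound 3 are both reported in this assay only as "not active", without a number, so no step can be read between them. From the compounds shown here alone, what replacing 2-ethylphenyl with octyl does to potency stays open. Nothing shown offers an explanation for this result.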